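A few compounds are considered here, and "the series" means these few. Any claim that something is new, unique, unknown or untested is made for them only; others in the source may bear on it.

Of the compounds shown here, three have been measured in an assay on Sf9 cells for inhibition of protein deacetylase HDAC6 (Homo sapiens), read by fluorescence; on this read-out higher numbers stand for weaker inhibition and lower numbers for stronger inhibition. Compound 1 `NCc1ccc(C(=O)NO)cc1` gives 695 nM in this assay. Compound 2 `Nc1ccc(C(=O)NO)cc1` gives 1400 nM in this assay. Compound 3 `Nc1ccc(-c2nnn(Cc3ccc(C(=O)NO)cc3)n2)cc1` is built on a much larger core and gives 1 nM in this assay, the lowest of the three numbers, with both other compounds beyond the scatter from it. How the core of compound 3 differs from the core of compound 2 is not broken down here.

Between compound 2 and compound 1 a single change is made: aminomethyl in place of amino on an aromatic carbon. The step that goes with it is a 2.0-fold lower number from compound 2 to compound 1 (0.30 log units; within the scatter).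

Compound 4 `NCc1ccc(-c2nnn(Cc3ccc(C(=O)NO)cc3)n2)cc1` has not yet been measured. It differs from compound 3 by aminomethyl in place of amino on an aromatic carbon. Among the compounds with values here, this is the same kind of change as the one between compound 2 and compound 1, but not the same change: in compound 1 the entering group sits para to a group of 4 heavy atoms, whereas in compound 4 it sits para to a large group.

Within the data shown here, because the one earlier example of this kind of change gave a 2.0-fold lower number from compound 2 to compound 1 (0.30 log units; within the scatter), a step of similar size is expected here. Compound 4 is expected to give about 1.3 nM in this assay, with a range from 0.4 nM to 4 nM. The estimate means an expected step of a 1.3-fold higher number from compound 3 to compound 4 (0.11 log units; within the scatter). Among the measured compounds shown here, only one prior example supports it, so the range is kept wide.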

Compound 4, half-maximal inhibitory concentration: 2 nM
Beside the measured number, compound 4's estimate is 1.5-fold (0.19 log units) below it, and the stated range covers the measured number.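

In this assay, putting aminomethyl in place of amino on the larger core gives a 2.0-fold higher number from compound 3 to compound 4 (0.30 log units; within the scatter), so taken alone this step is no larger than the differences expected between repeated measurements, and the same is true of the earlier step on the smaller core. Set side by side, however, the two steps point in opposite directions, and the gap between them is larger than the scatter of two such steps, so the change does not carry over unaltered from one core to the other: the same change on two cores in this assay, a 2.0-fold lower number (0.30 log units; within the scatter) from compound 2 to compound 1 and a 2.0-fold higher number (0.30 log units; within the scatter) from compound 3 to compound 4, 4.0-fold (0.61 log units) apart, beyond the scatter of two such steps This does not show what in the two cores sets the steps apart, and with a single pair on each core it cannot predict how the change would read on a third core.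

The compounds shown leave open how a longer chain such as aminoethyl, or a carboxylic acid, would read in the same place on either core. They also leave open whether the gap between the two steps would hold up across further pairs of compounds that carry amino and aminomethyl on other cores.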